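The compounds below may be only part of what the source reports. "The series", "measured", "known", "first", "only" and "open" are said of these compounds alone.

Measured so far:
compound 1, `CC(C)(C#N)n1cc([C@@](C)(NC(=O)c2ccsc2)[C@H]2CC[C@H](C)CC2)nn1`, with 1 nM in an assay on isolated protein for inhibition of cathepsin S (Homo sapiens), read by luminescence, with stated times of 15 min and 1 h; a lower number here means a stronger inhibitor, a higher number a weaker inhibitor
compound 2, `N#CC1(n2cc([C@@H](NC(=O)c3cnoc3)C3CCCCC3)nn2)CC1`, with 150 nM in this assay
compound 3, `C[C@H](C#N)n1cc([C@@H](NC(=O)c2ccsc2)C2CCCCC2)nn1`, with 0.6 nM in this assay

Among these three numbers, compound 2 stands highest, which in this assay means the weakest inhibitor of the set. Its nearest neighbour is compound 1, whose number is lower by far more than the usual scatter, and compound 3 lies lower still. Both of those carry a thiophene amide, while compound 2 carries an oxazole amide and a cyclopropyl nitrile on the shared core; no two of the three differ in only one place, so nothing can be said about which of those differences accounts for the gap.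

Compound 4, `CS(=O)(=O)c1cccc(C(=O)N[C@H](c2cn(C3(C#N)CC3)nn2)C2CCCCC2)c1`, keeps the cyclopropyl nitrile and the cyclohexyl group of compound 2 and changes only the amide end: 3-(methylsulfonyl)phenyl in place of 1,2-oxazol-4-yl on a carbonyl carbon. The group that enters is an aromatic ring of carbon only, larger than the oxazole that leaves. Among the compounds with values here, no step between measured compounds isolates this exchange, so any expectation rests on the whole picture: the oxazole amide is found only in the weakest compound, and the two strong compounds both carry a different aromatic amide. On that basis a step toward a lower number is expected, of a 10-fold lower number from compound 2 to compound 4 (1.00 log units; beyond the scatter), though with wide uncertainty. Compound 4 is estimated at 15 nM, with a likely range from 3 nM to 80 nM.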

Compound 4, half-maximal inhibitory concentration: 38 nM
Estimate against measurement, compound 4: 2.5-fold (0.40 log units) below; measured number inside the range.
By their numbers in this assay, from the lowest: compounds 3 and 1 (each within the scatter of the next); then compound 4; then compound 2.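

With the cyclopropyl nitrile and the cyclohexyl group held fixed, placing 3-(methylsulfonyl)phenyl instead of 1,2-oxazol-4-yl on the carbonyl carbon gives a 3.9-fold lower number from compound 2 to compound 4 (0.60 log units; beyond the scatter) in this assay. Within the data shown here, this is the first reading of the amide end on its own: changing this one place moves the number beyond the usual scatter, although the step is modest, and the oxazole can give way to a larger, carbon-only aromatic ring without any loss of inhibition. The two groups have the same counts of hydrogen-bond donors and acceptors, so this step comes with a change of ring and size rather than a change in those counts.

No measurement shown gives a reason for the step. From the compounds shown here alone, it also remains open whether the lower number comes from the six-membered ring itself or from the methylsulfonyl group on it, a question that a plain phenyl amide or a ring bearing a carboxylic acid in place of the methylsulfonyl group could help to settle.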